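From Ethyl to Acetyl on a Ring Amine Nitrogen

A few compounds are considered here, and "the series" means these few. Any claim that something is new, unique, unknown or untested is made for them only; others in the source may bear on it.

Measured so far, for the half-life in an ADME assay on microsomes from liver (Mus musculus) for metabolic stability, read by LC-MS, using NADPH, with stated times of 15 min and 60 min, tested at 4.6 uM; a lower number here means that the compound disappears faster, a higher number that the compound lasts longer:
compound 1, `O=C(NCCCCc1ccccc1)n1c2c(oc1=O)CNCC2`: compound 1 gives < 0.25 h.
compound 2, `CCN1CCC(c2ccc3c(c2)oc(=O)n3C(=O)NCCCCc2ccccc2)CC1`: compound 2 gives 1 h.
compound 3, `CCCCCNC(=O)n1c(=O)oc2cc(C3CCN(C)CC3)ccc21`: compound 3 gives > 1 h.

The value of compound 1 is a limit of this assay, not a number, and it is one of the two limits among the three values (the limit of < 0.25 h in this assay, at which 1 of the 3 values shown sits). The value of compound 3 is likewise a limit of this assay (the limit of > 1 h in this assay, at which 1 of the 3 values shown sits). Among the compounds with values here, compound 2 therefore stands as the only value that is a number proper; the other two results are limits, so nothing about the order of the three can be read from them.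

Within the data shown here, no pair of the measured compounds differs in a single place, so no single change has yet been followed with a measured step.

Compound 4, `CC(=O)N1CCC(c2ccc3c(c2)oc(=O)n3C(=O)NCCCCc2ccccc2)CC1`, differs from compound 2 in one place: acetyl in place of ethyl on an amine nitrogen in a ring. Without a measured step to lean on, the expectation rests on compound 2 alone, which gives 1 h in this assay. The step from compound 2 to compound 4 is expected to be small, no change at the digits printed from compound 2 to compound 4 (within the scatter), not beyond the scatter in either direction. Compound 4 is accordingly estimated at 1 h, with a range from 0.4 h to 2.5 h.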

Compound 4, half-life: 1 h
For compound 4 middle estimate and measured number coincide at the digits printed, and the stated range covers the measured number.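

In this assay, within the data shown here, the first single change that can be followed gives no change at the digits printed from compound 2 to compound 4 (within the scatter). At this amine nitrogen in a ring, 1-ethylpiperidin-4-yl and 1-acetylpiperidin-4-yl therefore read alike, even though the entering acetyl adds a carbonyl and a hydrogen-bond acceptor that the leaving ethyl lacks, and the nitrogen position thus tolerates this exchange with no measurable shift in half-life. Compound 3 stands at a limit of this assay, and the reading shared by the pair sits at the same figure, so their agreement lies at the edge of what this assay reports as a number: the limit of > 1 h in this assay, at which 1 of the 4 values shown sits.

The compounds shown leave open whether other groups on this nitrogen, such as a sulfonyl group, a carboxylic acid or a longer chain, would read the same way as ethyl and acetyl. As far as these compounds go, compound 1 and compound 3 each differ from this pair in more than one place, so it also remains open whether the exchange of ethyl for acetyl would behave the same way on a different core or with a different chain.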